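The compounds below may be only part of what the source reports. "The series", "measured", "known", "first", "only" and "open" are said of these compounds alone.

Compound 1 `C#CCOC(=O)C1=C(N)Oc2ccc(-c3cc(OC)cc(OC)c3)cc2C1CC(=O)c1ccccc1`: 5900 nM; compound 2 `C#CCOC(=O)C1=C(N)Oc2ccc(-c3cc(OC)cc(OC)c3)cc2C1CC(O)c1ccccc1`: 54000 nM.

In a functional assay on HL60/MX2 cells (Homo sapiens) for inhibition, with a stated time of 48 h (on this read-out lower numbers stand for stronger inhibition and higher numbers for weaker inhibition), compound 1 stands lowest of the two measured compounds. Within the data shown here, the only measured step, a 9.2-fold higher number from compound 1 to compound 2 (0.96 log units; beyond the scatter), concerns the group on the saturated chain carbon bound to a saturated ring carbon. Compound 3 `CCOC(=O)C1=C(N)Oc2ccc(-c3cc(OC)cc(OC)c3)cc2C1CC(=O)c1ccccc1` differs from compound 1 elsewhere: methyl in place of ethynyl on a saturated chain carbon bound to an oxygen next to a carbonyl group. Among the measured compounds shown here, no measured step touches this position, so the expected change is a 1.2-fold higher number from compound 1 to compound 3 (0.07 log units; within the scatter), no further than the scatter. Compound 3 is therefore expected to give about 7000 nM, between 2500 nM and 20000 nM.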

Compound 3, half-maximal inhibitory concentration: 41000 nM
Estimate against measurement, compound 3: 5.9-fold (0.77 log units) below; the whole stated range lies below it.
By their numbers in this assay, from the lowest: compound 1; then compounds 3 and 2 (each within the scatter of the next).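

In this assay, methyl in place of ethynyl on a saturated chain carbon bound to an oxygen next to a carbonyl group gives a 6.9-fold higher number from compound 1 to compound 3 (0.84 log units; beyond the scatter). This position, which the earlier step did not touch, therefore also bears on the read-out, with propargyloxycarbonyl going with the lower number of this pair. Nothing measured here gives a reason for this difference. The compounds shown leave open how a longer chain or a phenyl group at this position would read, and whether a carboxylic acid could replace propargyloxycarbonyl.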